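Compound 3: an amide in place of the benzyl ester

The compounds below may be only part of what the source reports. "The series", "measured", "known", "first", "only" and "open" are said of these compounds alone.

Compound 1 `CNC(=O)c1cc(Oc2ccc3c(C)c(C(=O)O)sc3c2)ccn1`: > 100000 nM (a limit)
Compound 2 `CNC(=O)c1cc(Oc2ccc3c(C)c(C(=O)OCc4ccccc4)sc3c2)ccn1`: 18800 nM

Both values come from an ADME assay on H1-HeLa cells (Homo sapiens) for cytotoxicity, read by MTT assay, with a stated time of 3 days; on this read-out lower numbers stand for higher toxicity in this test and higher numbers for lower toxicity in this test. Within the data shown here, compound 2 carries the only true number so far. Compound 1 sits at the limit of > 100000 nM in this assay, at which 1 of the 2 values shown sits. Compound 3 `CCNC(=O)c1sc2cc(Oc3ccnc(C(=O)NC)c3)ccc2c1C` differs from compound 2 by ethylamino in place of benzyloxy on a carbonyl carbon. Among the measured compounds shown here, the one measured step bearing on this change is an at least 5.3-fold lower number from compound 1 to compound 2 (0.72 log units; beyond the scatter). The benzyl that entered in that step leaves again here, so a partial return towards higher numbers is expected, with an estimated 2.4-fold higher number from compound 2 to compound 3 (0.38 log units; beyond the scatter). For compound 3 the estimate is 45000 nM, with an expected range of 18000 nM to 100000 nM.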

Compound 3, half-maximal cytotoxic concentration: > 100000 nM
Compound 3 gave a limit, no number (the forecaster's own chance of this, stated with the estimate: 35%); at least 2.2-fold (0.34 log units) between middle value and limit.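

Replacing benzyloxy with ethylamino on the carbonyl carbon gives an at least 5.3-fold higher number from compound 2 to compound 3 (0.72 log units; beyond the scatter) in this assay, so the lower number of the benzyl ester does not carry over to the ethyl amide. Compound 3 reads > 100000 nM, which is a limit and not a number. The step from compound 1 to compound 3 cannot be read: the limit of > 100000 nM in this assay, at which 2 of the 3 values shown sit.

Open, going by these compounds, is whether the lower number follows the aromatic ring of benzyloxy or the ester oxygen; a benzyl amide and a methyl ester would separate the two. Also open, on these data alone, is how a longer chain on the amide nitrogen would read.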